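The source may hold more compounds than are shown below. What is called first, only, known or untested is meant among the compounds shown, and "the series" means these compounds.

Three measured compounds share one core and differ only in the group on a saturated chain carbon bound to a sulfur. In a functional assay on MCF7 cells (Homo sapiens) for inhibition, read by MTT assay, with a stated time of 72 h (a lower number here means a stronger inhibitor, a higher number a weaker inhibitor), compound 1 (`Cc1cc(Nc2cc(-c3ccccc3)[nH]n2)n2nc(SCc3ccc([N+](=O)[O-])cc3)nc2n1`) gives 5060 nM and compound 2 (`Cc1cc(Nc2cc(-c3ccccc3)[nH]n2)n2nc(SCC(=O)c3ccccc3)nc2n1`) gives 5240 nM while compound 3 (`Cc1ccc(CSc2nc3nc(C)cc(Nc4cc(-c5ccccc5)[nH]n4)n3n2)cc1`) gives 7290 nM as its reading. Compound 3 therefore cannot be ranked against the others, since its value lies within the usual scatter of both. Compound 4 (`Cc1cc(Nc2cc(-c3ccccc3)[nH]n2)n2nc(SCc3csc4ccccc34)nc2n1`) differs from compound 3 at that same place, with 1-benzothiophen-3-yl in place of 4-methylphenyl. The counted change is 1-benzothiophen-3-yl in place of 4-methylphenyl on a saturated chain carbon bound to a sulfur and nothing else in the structure differs. The measured steps that bear on it are small: a 1.4-fold higher number from compound 1 to compound 3 (0.16 log units; within the scatter) and a 1.4-fold higher number from compound 2 to compound 3 (0.14 log units; within the scatter) and also a 1.0-fold higher number from compound 1 to compound 2 (0.02 log units; within the scatter) all stay within the scatter. Among the compounds with values here, no measured compound carries 1-benzothiophen-3-yl, so this is a cautious guess, and no step beyond the scatter is expected in this assay here. The expected change is a 1.3-fold lower number from compound 3 to compound 4 (0.12 log units; within the scatter) and it would not stand out from the scatter. For compound 4 the estimated value is 5500 nM with an expected range from 2300 nM to 12000 nM in this measurement.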

Compound 4, half-maximal inhibitory concentration: 3470 nM
Compound 4: middle estimate off by 1.6-fold (0.20 log units), on the high side; low and high end bracket the measured number.
By their numbers in this assay, from the lowest: compounds 4, 1, 2 and 3 (each within the scatter of the next, the first and the last beyond it).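

In this assay, this position now shows its first step beyond the scatter: 1-benzothiophen-3-yl in place of 4-methylphenyl gives a modest gain (a 2.1-fold lower number from compound 3 to compound 4 (0.32 log units; beyond the scatter)). That gain holds only against compound 3, since the new group does not separate from benzoyl (a 1.5-fold lower number from compound 2 to compound 4 (0.18 log units; within the scatter)) or from 4-nitrophenyl (a 1.5-fold lower number from compound 1 to compound 4 (0.16 log units; within the scatter)), so the position shows a shallow response to these changes rather than a clear order. No measurement on hand explains the step, and no reason for it can be offered.

As far as these compounds go, it remains open whether the sulfur or the second ring of the new group matters, and a naphthyl group, which has two rings and no sulfur, would help to separate the two. From the compounds shown here alone, how an amine or a carboxylic acid would read at this place also remains open.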